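The source may report more compounds than this note shows. Statements on the series, on what has been measured and on what is new or still open speak of the compounds shown alone.

Compound 3 `CSc1nc(N(C)C)c2ncn([C@@H]3C[C@@H](O)[C@H](CO)O3)c2n1`: 260 uM
Compound 2 `Nc1nc(Br)nc2c1ncn2[C@@H]1C[C@@H](O)[C@H](CO)O1`: 1.6 uM
Compound 1 `CN(C)c1nc(N)c2ncn([C@@H]3C[C@@H](O)[C@H](CO)O3)c2n1`: a limit, > 300 uM

In a functional assay on PHA-Ly cells (Homo sapiens) (a lower number here means a stronger inhibitor, a higher number a weaker inhibitor), compound 3 gives 260 uM, the highest of the two numbers. Compound 2 gives 1.6 uM in this assay, far below it. Compound 1 reaches only the assay limit, > 300 uM. Among the compounds with values here, the single measured step, an at least 180-fold lower number from compound 1 to compound 2 (2.27 log units; beyond the scatter), is large, and the limit of > 300 uM in this assay, at which 1 of the 3 values shown sits, leaves its true size open. Compound 4 `CSc1nc(N)c2ncn([C@@H]3C[C@@H](O)[C@H](CO)O3)c2n1` differs from compound 3 by amino in place of dimethylamino on an aromatic carbon. Within the data shown here, no measured step covers this change itself; compound 1 and compound 2 both already carry the amino, and compound 2 shows that such a core can reach a low number. The step of a 13-fold lower number from compound 3 to compound 4 (1.11 log units; beyond the scatter) is therefore expected to lean downward, though with little support. Compound 4 is estimated at 20 uM, within 3 uM to 150 uM.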

Compound 4, concentration for 50% inhibition: 82 uM
For compound 4 the middle estimate is 4.1-fold (0.61 log units) below the measured one, within the range that was stated.
By their numbers in this assay, from the lowest: compound 2; then compound 4; then compound 3. At a limit, above all of these: compound 1.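

In this assay, amino in place of dimethylamino on this aromatic carbon now has a measured size, and it is modest: a 3.2-fold lower number from compound 3 to compound 4 (0.50 log units; beyond the scatter). With the amino kept, methylsulfanyl in place of bromo weighs far more, a 51-fold higher number from compound 2 to compound 4 (1.71 log units; beyond the scatter), and the amino alone does not bring the low number of compound 2. Methylsulfanyl in place of dimethylamino gives an at least 3.6-fold lower number from compound 1 to compound 4 (0.56 log units; beyond the scatter), a step whose true size stays open: the limit of > 300 uM in this assay, at which 1 of the 4 values shown sits.

As far as these compounds go, whether chloro, methoxy or a longer alkylthio chain in place of methylsulfanyl would come near compound 2 stays open. So does where methylamino would fall in place of dimethylamino.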